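From chloro to diethoxymethyl on a shared core

A few compounds are considered here, and "the series" means these few. Any claim that something is new, unique, unknown or untested is made for them only; others in the source may bear on it.

In an ADME assay on HeLa cells (Homo sapiens) for cytotoxicity, read by resazurin assay, with a stated time of 2 days (a higher number here means a weaker inhibitor, a lower number a stronger inhibitor), compound 1 `Cn1c([N+](=O)[O-])cnc1/C=C/c1ccc(Br)cc1` gives 72400 nM and compound 2 `Cn1c([N+](=O)[O-])cnc1/C=C/c1ccc(Cl)cc1` gives 91200 nM as its number. These two values lie within the scatter of each other, so compound 2 stands level with compound 1 and the pair cannot be told apart.

Compound 3 `CCOC(OCC)c1ccc(/C=C/c2ncc([N+](=O)[O-])n2C)cc1` keeps the core of compound 2 and differs in one place (diethoxymethyl in place of chloro on an aromatic carbon), with diethoxymethyl in place of chloro on an aromatic carbon. For the measured compounds named here, the only measured step that bears on this is a 1.3-fold higher number from compound 1 to compound 2 (0.10 log units; within the scatter) for chloro in place of bromo on an aromatic carbon. That step shows a swap at the same place leaving the number unmoved, but it involved only two single atoms. It says little about a group as different as diethoxymethyl, and the data give no direction. In this assay the expected step is a 1.1-fold lower number from compound 2 to compound 3 (0.06 log units; within the scatter) and so no shift beyond the scatter is predicted, though with wide uncertainty. For compound 3 the estimate is 80000 nM with 30000 nM to 200000 nM as the expected range.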

Compound 3, half-maximal inhibitory concentration: 97700 nM
Compound 3: middle estimate off by 1.2-fold (0.09 log units), on the low side; low and high end bracket the measured number.
By their numbers in this assay, from the lowest: compounds 1, 2 and 3 (each within the scatter of the next).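

In this assay, a 1.1-fold higher number from compound 2 to compound 3 (0.03 log units; within the scatter) comes with diethoxymethyl in place of chloro, and a 1.3-fold higher number from compound 1 to compound 3 (0.13 log units; within the scatter) comes with diethoxymethyl in place of bromo. The earlier pair only traded one single atom for another, whereas here a group of 7 heavy atoms, with 2 hydrogen-bond acceptors, replaces that single atom on the aromatic carbon, and compounds 1, 2 and 3 still cannot be told apart. So, across these three compounds, a much larger change at this place leaves the number level, and no supporting measurement is available to explain this result.

The compounds shown leave open whether any group at this place can move the number beyond the scatter, since all three substituents here carry no net charge. An amine or a carboxylic acid on the same aromatic carbon would test that question, and a longer chain than diethoxymethyl would show whether the level result holds for still larger groups.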